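Methyl for fluoro on the fused benzene ring of compound 2

The source may report more compounds than this note shows. Statements on the series, on what has been measured and on what is new or still open speak of the compounds shown alone.

Working notes on a small indole series tested in an in vitro assay on P815B cells for inhibition of Indoleamine 2,3-dioxygenase 1 (Mus musculus), tested at 20 uM; a higher number here means more inhibition at the concentration tested (going by the name of the read-out), a lower number less inhibition. Three compounds have numbers or a verdict. Compound 1 `OC(Cc1cccnc1)c1cc2ccccc2[nH]1`, the alcohol, gives "not active" (no number reported) in this assay. Compound 3 `COc1cccc2[nH]c(C(=O)Cc3cccnc3)cc12`, with the methoxy group, likewise gives "not active" (no number reported) in this assay. For the measured compounds named here, compound 2 `O=C(Cc1cccnc1)c1cc2cc(F)ccc2[nH]1`, carrying the fluoro group, is the only member with a number: in this assay compound 2 gives 24%, a modest read-out, and the two remaining entries have no number at all, so compound 2 stands alone as the only measurable point in the set.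

Compound 4 `Cc1ccc2[nH]c(C(=O)Cc3cccnc3)cc2c1` has not yet been tested. Its difference from compound 2 is methyl in place of fluoro on an aromatic carbon. Going by the values given here, no pair of measured compounds differs in one place, so no measured step is available to calibrate this change. Given that, the step from compound 2 to compound 4 is expected to stay within the usual scatter of this assay, with no direction claimed beyond it; the expected step is a number 6 percentage points lower from compound 2 to compound 4 (within the scatter). For compound 4 the value in this assay is estimated at 18%, with a range from 0% to 40%, and a real chance that only "not active" is reported, as for compound 1 and compound 3.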

Compound 4, a percentage reported as inhibition, at one concentration (the size of the read-out at that concentration, not a potency): 21%
For compound 4 the middle estimate is 3 percentage points below the measured one; the measured number falls inside the stated range.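

In this assay the series now has its first step between compounds that differ in one place, a number 3 percentage points lower from compound 2 to compound 4 (within the scatter), and at this position, on an aromatic carbon meta to a fused ring and para to a fused ring, compounds carrying methyl and fluoro cannot be told apart. For the compounds shown here, the earlier compounds offered no such pair, and with this result compound 2 is no longer the only compound with a number, which means a measurable read-out is not tied to the fluoro group alone. Nothing measured bears on why the two groups read alike, and the step stands only as an observation.

As far as these compounds go, whether an amine, a carboxylic acid or a longer chain on this same aromatic carbon would still give a number in this assay stays open, and a single step says nothing about how other groups would read here. Also open, from the compounds shown here alone, is what separates the entries reported as not active from those with a number: compound 1 and compound 3 each differ from compound 2 and compound 4 in more than one place, and the steps to them cannot be read.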